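A Chloro Group and Binding at the Nicotinic Receptor

This account rests on a few compounds, and the source may have more. Where it says the series, first, only, none or still open, it means among the compounds named here.

Measured compounds:
compound 1, `Brc1cncc(OC[C@@H]2CCN2)c1`, gives 0.18 nM in an assay on brain for binding affinity to Neuronal acetylcholine receptor; alpha4/beta2 (Rattus norvegicus), read by radioligand binding; a higher number here means a weaker inhibitor, a lower number a stronger inhibitor
compound 2, `Cc1ncccc1OC[C@@H]1CCN1`, gives 1.36 nM in this assay
compound 3, `Clc1ncc(OC[C@@H]2CCN2)cc1Br`, gives 0.015 nM in this assay

Compound 2 has the highest number of the three and is the weakest binder among them. The change from compound 1 to compound 3 is chloro in place of hydrogen on an aromatic carbon, and the step it made is a 12-fold lower number from compound 1 to compound 3 (1.08 log units; beyond the scatter). Compound 4, `Cc1nc(Cl)ccc1OC[C@@H]1CCN1`, has not been measured; it differs from compound 2 by chloro in place of hydrogen on an aromatic carbon. This is the same kind of change, though the surroundings differ: in compound 3 the chloro is ortho to a bromo group, in compound 4 it is meta to a methyl group. The difference between the cores of compound 1 and compound 2 is not broken down here. A step from compound 2 to compound 4 of a 9.1-fold lower number from compound 2 to compound 4 (0.96 log units; beyond the scatter) is expected, because the earlier step was a 12-fold lower number from compound 1 to compound 3 (1.08 log units; beyond the scatter) and the surroundings are only partly alike. Compound 4 is therefore estimated at 0.15 nM, most likely between 0.04 nM and 0.6 nM.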

Compound 4, inhibition constant: 2.4 nM
The estimate for compound 4 lay 16-fold (1.20 log units) below the measured number, and the stated range ends below it.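

On the core of compound 2, the chloro group does not repeat what it did on the core of compound 1: in this assay the step is a 1.8-fold higher number from compound 2 to compound 4 (0.25 log units; within the scatter), so compound 2 and compound 4 cannot be told apart. The same change therefore does not carry over at the same size between these two cores: the same change on two cores in this assay, a 12-fold lower number (1.08 log units; beyond the scatter) from compound 1 to compound 3 and a 1.8-fold higher number (0.25 log units; within the scatter) from compound 2 to compound 4, 21-fold (1.33 log units) apart, beyond the scatter of two such steps

Going by these compounds alone, with only two pairs, this shows that a step on one core is a poor guide to the step on the other, but not which difference between the cores is responsible. The compounds shown leave open how another group in that place, such as methoxy or an amine, would behave on the core of compound 2. They also leave open how chloro would behave on a core carrying neither the bromo nor the methyl group.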